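This account rests on a few compounds, and the source may have more. Where it says the series, first, only, none or still open, it means among the compounds named here.

In a functional assay on KOPN-8 cells (Homo sapiens) for antiproliferative activity, with a stated time of 72 h (on this read-out higher numbers stand for an effect only at larger amounts of compound and lower numbers for an effect already at smaller amounts), compound 1 `COc1ccc(-c2c(Cl)c(=O)c3c(OC)cc(OC)cc3n2S(=O)(=O)c2ccc(OC)cc2)cc1` gives 19100 nM and compound 3 `COc1cc(OC)c2c(=O)cc(C(=O)Nc3ccc(C4CCCCC4)cc3)[nH]c2c1` gives 18400 nM, and the two numbers sit within the scatter of each other. Compound 2 `COc1ccc(-c2cc(=O)c3c(OC)cc(OC)cc3n2S(=O)(=O)c2cc(Cl)cc(Cl)c2O)cc1` reaches only the limit of > 37900 nM in this assay, so it yields no number (the limit of > 37900 nM in this assay, at which 1 of the 3 values shown sits). Compound 3 therefore stands alongside compound 1, with compound 2 beyond the limit. Compound 4 `COc1cc(OC)c2c(=O)cc(C(=O)Nc3ccc(N4CCN(C)CC4)cc3)[nH]c2c1` differs from compound 3 in one place: 4-methylpiperazin-1-yl in place of cyclohexyl on an aromatic carbon. Going by the values given here, no measured pair shows the effect of such a swap, and compound 1 and compound 3, though quite different in structure, land close together. A step from compound 3 to compound 4 of a 1.2-fold lower number from compound 3 to compound 4 (0.09 log units; within the scatter) is expected, not beyond the scatter. Compound 4 is estimated at 15000 nM, with a range from 5000 nM to 45000 nM.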

Compound 4, half-maximal effective concentration: > 19800 nM
Compound 4 ended at the assay's limit; the forecaster's own chance of this, stated with the estimate: 25%; at least 1.3-fold (0.12 log units) between middle value and limit.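

Compound 4 gives no number in this assay, only a limit: the limit of > 19800 nM in this assay, at which 1 of the 4 values shown sits. Putting 4-methylpiperazin-1-yl in place of cyclohexyl on this aromatic carbon gives an at least 1.0-fold higher number from compound 3 to compound 4 (0.03 log units; that floor lies within the scatter). Going by these compounds alone, this is the first reading at this position: the new ring with two nitrogens brought no lower number, and how far the true value lies past the floor cannot be read.

The compounds shown leave open whether a morpholine ring, a simple amine or a carboxylic acid at this place would give a lower number. They also leave open whether any change here moves the number beyond the scatter.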